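The source may hold more compounds than are shown below. What is called first, only, known or untested is meant among the compounds shown, and "the series" means these compounds.

Measured compounds:
compound 1 `O=C1/C(=C/c2ccccc2)Cc2cc(O)ccc21` with 1940 nM
compound 2 `O=C1/C(=C/c2ccccc2)Cc2ccc(O)cc21` with 440 nM
compound 3 `O=C1/C(=C/c2ccc(F)cc2)Cc2cc(O)ccc21` with 679 nM

In an assay on isolated protein for inhibition of Amine oxidase [flavin-containing] A (Homo sapiens), read by fluorescence and spectrophotometry, with a stated time of 20 min (a higher number here means a weaker inhibitor, a lower number a stronger inhibitor), compound 1 gives 1940 nM, the highest of the three numbers: compound 3, nearest to it, gives 679 nM, and compound 2, furthest, gives 440 nM. Compound 4 `O=C1/C(=C/c2cccc(Cl)c2)Cc2cc(O)ccc21` differs from compound 1 by chloro in place of hydrogen on an aromatic carbon. Within the data shown here, the one measured step that bears on it is the halogen step on the same core, a 2.9-fold lower number from compound 1 to compound 3 (0.46 log units; beyond the scatter), a modest shift to a stronger inhibitor. Among the measured compounds shown here, that step carries a different halogen, and no pair with chloro at any place has been measured, so the transfer is loose; the step from compound 2 to compound 1 concerns the hydroxyl and does not speak to the change here. A shift of similar size and direction is therefore expected, with a range wide enough to include no shift beyond the scatter: for compound 4 the estimate in this assay is 900 nM, between 300 nM and 2500 nM, corresponding to an expected step of a 2.2-fold lower number from compound 1 to compound 4 (0.33 log units; beyond the scatter).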

Compound 4, half-maximal inhibitory concentration: 157 nM
Beside the measured number, compound 4's estimate is 5.7-fold (0.76 log units) above it; measured number below the stated range.
By their numbers in this assay, from the lowest: compound 4; then compounds 2 and 3 (each within the scatter of the next); then compound 1.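

In this assay, chloro in place of hydrogen on an aromatic carbon, meta to a large group, gives a 12-fold lower number from compound 1 to compound 4 (1.09 log units; beyond the scatter), so one substituent on this ring can move the number much further than the only earlier halogen step, a 2.9-fold lower number from compound 1 to compound 3 (0.46 log units; beyond the scatter), had shown. Those two steps differ in both the halogen and its place on the ring, so the larger shift cannot be assigned to either alone. Nothing shown accounts for the size of the chloro step.

Still open, going by these compounds, is how fluoro at this same place compares with chloro, and whether a methoxy group, a nitrile or an amine there would give a step of similar size. On these data alone, it is also open whether chloro at this place gives a comparable step on the core of compound 2, which carries its hydroxyl elsewhere.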